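The compounds below may be only part of what the source reports. "The series", "measured", "known", "first", "only" and "open" are said of these compounds alone.

Measured compounds:
compound 1, `Clc1ccccc1-c1ccc2[nH]ncc2c1`, in an assay on CHO-TREX cells for antagonist activity at transient receptor potential cation channel subfamily A member 1 (Homo sapiens), read by FLIPR and calcium flux, with a stated time of 10 min (a lower number here means a stronger inhibitor, a higher number a weaker inhibitor), compound 1 gives 1230 nM
compound 2, `Cc1ccccc1-c1ccc2[nH]ncc2c1`; compound 2 gives 7810 nM
compound 3, `CCc1ccccc1-c1ccc2[nH]ncc2c1`; compound 3 gives 584 nM

Compound 3 holds the lowest of the three numbers. The steps of a 2.1-fold lower number from compound 1 to compound 3 (0.32 log units; beyond the scatter) and a 13-fold lower number from compound 2 to compound 3 (1.13 log units; beyond the scatter) both run downward to it, and the step of a 6.3-fold higher number from compound 1 to compound 2 (0.80 log units; beyond the scatter) shows that the three groups on the aromatic carbon are not interchangeable within the scatter.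

Compound 4, `FC(F)c1ccccc1-c1ccc2[nH]ncc2c1`, differs from compound 3 by difluoromethyl in place of ethyl on an aromatic carbon. Going by the values given here, no step with difluoromethyl has been measured. What bears on it is that every change at this carbon so far has moved the number beyond the scatter, and that only ethyl has given the lowest number. A step back toward the range of compound 1 is therefore expected, modest in size, in the direction of a higher number: a 1.5-fold higher number from compound 3 to compound 4 (0.19 log units; within the scatter) is the estimated step. For compound 4 the estimate is 900 nM, with a range from 300 nM to 3000 nM.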

Compound 4, half-maximal inhibitory concentration: 2200 nM
For compound 4 the middle estimate is 2.4-fold (0.39 log units) below the measured one; the range from low to high includes it.
By their numbers in this assay, from the lowest: compound 3; then compounds 1 and 4 (each within the scatter of the next); then compound 2.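

In this assay, difluoromethyl on this aromatic carbon does not match ethyl, giving a 3.8-fold higher number from compound 3 to compound 4 (0.58 log units; beyond the scatter), yet it stands clear of methyl, giving a 3.6-fold lower number from compound 2 to compound 4 (0.55 log units; beyond the scatter). Against chloro the change gives a 1.8-fold higher number from compound 1 to compound 4 (0.25 log units; within the scatter), which makes difluoromethyl and chloro the first two groups at this carbon that the assay does not separate. No measurement is at hand that would explain these differences between groups.

Still open, from the compounds shown here alone, is whether a longer chain such as propyl, a branched chain such as isopropyl, or a methoxy or trifluoromethyl group on this carbon would give a number lower than that of compound 3. Also open, going by these compounds, is whether the order of ethyl, chloro, difluoromethyl and methyl would hold with an amine or a carboxylic acid elsewhere on the shared core.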